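Swapping an Acetamido for a Methyl on a Hydroxamic Acid

The source may hold more compounds than are shown below. What is called first, only, known or untested is meant among the compounds shown, and "the series" means these compounds.

The compounds here share a core in which a hydroxamic acid hangs from a ring-fused chain, with a varying group attached through the ring nitrogen. Compound 1 `CC(=O)Nc1ccc(CN2CCC=C(CCC(=O)NO)C2=O)cc1` carries an acetamido-bearing benzyl group. In a functional assay on ACHN cells (Homo sapiens) for inhibition, read by sulforhodamine B assay (a higher number here means a weaker inhibitor of growth, a lower number a stronger inhibitor of growth), compound 1 gives "not determined" (no result reported), so no number stands for it. Compound 2 `O=C(CCC1=CCCN(Cc2ccc3ccccc3c2)C1=O)NO`, which carries a naphthylmethyl group instead, likewise gives "not determined" (no result reported) in this assay. Going by the values given here, the only measured member is compound 3 `O=C(CCC1=CCCN(CCCCc2cccc3ccccc23)C1=O)NO`, in which a four-carbon chain links the core to a naphthalene; in this assay compound 3 gives 1820 nM.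

Compound 4 `Cc1ccc(CN2CCC=C(CCC(=O)NO)C2=O)cc1` is the compound awaiting measurement. It differs from compound 1 in one place: methyl in place of acetamido on an aromatic carbon. The change is methyl in place of acetamido on an aromatic carbon.

Among the compounds with values here, no pair of measured compounds differing in a single place is available, and compound 1 itself has no number, so no direction can be read from the data. The expectation for this assay is therefore a step of no clear direction, with no basis for calling it larger than the usual scatter. Taking compound 3 as the only anchor, compound 4 is estimated at 3000 nM, with a range from 700 nM to 13000 nM.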

Compound 4, concentration for 50% growth inhibition: 5000 nM
Beside the measured number, compound 4's estimate is 1.7-fold (0.22 log units) below it; the measured number falls inside the stated range.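

In this assay, going by these compounds alone, compound 4 gives 5000 nM, but compound 1 has no number to set against it, so no step between compound 1 and compound 4 can be read. The compounds shown leave open how methyl in place of acetamido changes growth inhibition. No evidence here bears on the value of compound 4.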